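The source may report more compounds than this note shows. Statements on the series, on what has been measured and on what is new or still open speak of the compounds shown alone.

Measured compounds:
- compound 1 `COC[C@H](NC1CCN(CCCc2c[nH]c3ccc(-n4cnnc4)cc23)CC1)c1ccccc1`: 93%
- compound 2 `C[C@@H](NC1CCN(CCCc2c[nH]c3ccc(-n4ccnc4)cc23)CC1)c1ccccc1`: 65%
- compound 3 `COC[C@H](NC1CCN(CCCc2c[nH]c3ccc(Cn4cncn4)cc23)CC1)c1ccc(F)cc1`: 89%

All three were tested in a functional assay on CHO cells for activation of 5-hydroxytryptamine receptor 1D (Homo sapiens), read by GTPgammaS binding; a higher number here means a larger maximal response, a lower number a smaller maximal response. Compound 1 gives 93%, the highest of the three numbers. Compound 3 gives 89%, a number that lies within the usual scatter of compound 1, so the two cannot be told apart. Compound 2 gives 65%, a number clearly lower than that of compound 1, beyond the scatter. Going by the values given here, no two of these three compounds differ in only one place, so no single structural step can be tied to any of these gaps.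

Compound 4 `CC(CO)(NC1CCN(CCCc2c[nH]c3ccc(-n4cnnc4)cc23)CC1)c1ccccc1` has not yet been measured in this assay. It shares the core of compound 1 and the same atoms, joined differently: 1-(hydroxymethyl)-1-phenylethyl in place of 2-methoxy-1-phenylethyl on an amine nitrogen. The group that enters carries one hydrogen-bond donor where the group that leaves carried none, and the defined stereocentre of compound 1 is gone.

Among the compounds with values here, no measured pair shows the effect of this kind of change, so the expectation rests on compound 1 alone and on the spread of the three numbers. The step from compound 1 to compound 4 is expected to be a number 13 percentage points lower from compound 1 to compound 4 (beyond the scatter), a modest decrease that may or may not exceed the scatter. Compound 4 is therefore estimated to reach 80% in this assay, within a range from 55% to 100%.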

Compound 4, largest response reached (reported as efficacy), in percent of the reference or control that the assay uses: 59%
For compound 4 the middle estimate is 21 percentage points above the measured one; the range from low to high includes it.
By their numbers in this assay, from the lowest: compounds 4 and 2 (each within the scatter of the next); then compounds 3 and 1 (each within the scatter of the next).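

In this assay, going by these compounds alone, putting 1-(hydroxymethyl)-1-phenylethyl in place of 2-methoxy-1-phenylethyl on the amine nitrogen gives the first step in this set that changes only one place (a number 34 percentage points lower from compound 1 to compound 4 (beyond the scatter)). This shows that the group on this nitrogen matters for the maximal response: the same atoms, joined differently, are enough to produce a large step on the core of compound 1. The change alters more than one feature at once, since the entering group carries a hydrogen-bond donor and the defined stereocentre is gone, and no measurement shown here explains the drop or separates these features.

The compounds shown leave open whether the loss follows the free hydroxyl, the missing stereocentre, or the new arrangement of methyl, phenyl and hydroxymethyl on one carbon. A 2-hydroxy-1-phenylethyl group on the same nitrogen would keep the hydroxyl on the original chain, while a 2-methoxy-1-methyl-1-phenylethyl group would keep the new branched carbon with the ether oxygen, so these two could begin to pull the features apart.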